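This account rests on a few compounds, and the source may have more. Where it says the series, first, only, none or still open, it means among the compounds named here.

Compound 1 `COc1ccc([C@@H]2[C@@H](C(=O)c3ccsc3)C(=O)N2c2cc(OC)c(OC)c(OC)c2)cc1` gives 470 nM in a functional assay on MCF7 cells (Homo sapiens) for antiproliferative activity, read by MTT assay; on this read-out lower numbers stand for stronger inhibition and higher numbers for weaker inhibition.
Compound 2 `COc1ccc([C@@H]2[C@@H](c3cccs3)C(=O)N2c2cc(OC)c(OC)c(OC)c2)cc1N` gives 42 nM in this assay.
Compound 3 `COc1ccc([C@@H]2C(c3ccsc3)C(=O)N2c2cc(OC)c(OC)c(OC)c2)cc1` gives 60 nM in this assay.

Among these three numbers, compound 1 has the highest, so it is the weakest inhibitor of the set: compound 3 sits beyond the scatter below it, and compound 2 sits further still below it. Compound 1 and compound 3 both carry a thiophen-3-yl ring on the shared core, but in compound 1 this ring hangs on a carbonyl carbon, while in compound 3 it sits directly on the saturated ring carbon; whatever else separates them, compound 1 comes out far weaker.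

The unmeasured compound 4 `COc1ccc([C@@H]2[C@@H](C(=O)c3cccs3)C(=O)N2c2cc(OC)c(OC)c(OC)c2)cc1` keeps the carbonyl of compound 1 and differs from it only in the thiophene ring: thiophen-2-yl in place of thiophen-3-yl on a carbonyl carbon. Among the measured compounds shown here, no step between two measured compounds isolates such a ring swap, so the expectation rests on the swap being small. In this assay the step from compound 1 to compound 4 is expected to be a 1.2-fold lower number from compound 1 to compound 4 (0.07 log units; within the scatter), within the scatter. Compound 4 is therefore estimated at 400 nM, with a range from 150 nM to 1200 nM.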

Compound 4, half-maximal inhibitory concentration: 950 nM
The estimate for compound 4 lay 2.4-fold (0.38 log units) below the measured number; measured number inside the range.
By their numbers in this assay, from the lowest: compounds 2 and 3 (each within the scatter of the next); then compound 1; then compound 4.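

Among the compounds shown here, compound 1 and compound 4 are the only pair here that differ in one place, so this is the first clean reading of the thiophene attachment on a carbonyl carbon: in this assay, the swap to thiophen-2-yl gives a 2.0-fold higher number from compound 1 to compound 4 (0.31 log units; beyond the scatter). The two rings carry the same atoms and the same counts, yet they are not fully interchangeable at this position, although the loss of activity is small and lies only just past the usual scatter. Nothing measured here explains the difference.

On these data alone, compound 2 and compound 3 differ in more than one place, so whether the same swap has a similar effect without the carbonyl stays open. Also open, as far as these compounds go, is how a plain phenyl or furan-2-yl ring would fare on this carbonyl carbon.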